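A few compounds are considered here, and "the series" means these few. Any claim that something is new, unique, unknown or untested is made for them only; others in the source may bear on it.

Of the compounds shown here, three have so far been tested in a functional assay on SMMC-7721 cells (Homo sapiens) for inhibition, read by MTT assay, with a stated time of 72 h, tested at 10 uM; on this read-out lower numbers stand for a weaker effect and higher numbers for a stronger effect at the one concentration tested. Compound 1 `Clc1ccc2c(O/N=C(/C=C/c3ccc(OCc4ccccc4Cl)cc3)\C=C\c3ccccn3)ncnc2c1` gives 84.7%, compound 2 `Clc1ccc(COc2ccc(/C=C/C(/C=C/c3ccccn3)=N/Oc3ncnc4cc(Cl)ccc34)cc2)c(Cl)c1` gives 23.6%, and compound 3 `Cc1cccc2ncnc(O/N=C(\C=C\c3ccccn3)/C=C/c3ccccc3OCc3ccc(Cl)cc3Cl)c12` gives 93.9%. Compound 1 differs from compound 2 by hydrogen in place of chloro on an aromatic carbon, and this single change made a step of a number 61.1 percentage points higher from compound 2 to compound 1 (beyond the scatter). Compound 4 `Cc1cccc2ncnc(O/N=C(\C=C\c3ccccn3)/C=C/c3ccccc3OCc3ccc(Cl)cc3)c12` has not yet been measured; it differs from compound 3 by hydrogen in place of chloro on an aromatic carbon. The difference between the core of compound 3 and the core of compound 2 is not broken down here. For the measured compounds named here, the change leading to compound 4 is the same kind of change as the one from compound 2 to compound 1, but the surroundings are not identical: in compound 1 the new hydrogen stands meta to a chloro group and para to a large group, whereas in compound 4 it stands ortho to a large group and meta to a chloro group. Because compound 3 already reaches 93.9%, little room is left upward, so the expected step is a number 5.9 percentage points lower from compound 3 to compound 4 (within the scatter). Compound 4 is therefore estimated at 88%, expected to fall between 62% and 100%.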

Compound 4, a percentage reported as inhibition, at one concentration (the size of the read-out at that concentration, not a potency): 94.5%
Compound 4: the middle estimate sits 6.5 percentage points below what was measured, within the range that was stated.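

On the core of compound 3, putting hydrogen in place of the chloro on the aromatic carbon gives a number 0.6 percentage points higher from compound 3 to compound 4 (within the scatter) in this assay, so 2,4-dichlorobenzyl and 4-chlorobenzyl cannot be told apart here. The large gain seen on the other core therefore does not carry over as a fixed effect of this change, and the two steps really do differ: the same change on two cores in this assay, a number 61.1 percentage points higher (beyond the scatter) from compound 2 to compound 1 and a number 0.6 percentage points higher (within the scatter) from compound 3 to compound 4, 60.5 percentage points apart, beyond the scatter of two such steps

This does not show why they differ, since the two pairs differ in their cores and in the surroundings of the chloro that leaves, and compound 3 already gives 93.9%, leaving little room for any gain on this scale; one pair per core cannot separate these points.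

The compounds shown carry only chloro or hydrogen at the changed places, so it stays open how a fluoro, a methoxy or an amine would read there. Also open, on these data alone, is how compound 3 and compound 4 would compare at lower concentrations, since a single concentration gives no potency.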